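The source may report more compounds than this note shows. Statements on the series, on what has been measured and on what is new or still open speak of the compounds shown alone.

Compound 1 `COc1ccc(/C=C/C(=O)c2ccc(OC)c3c2OC(C)(C)C=C3)cc1OCCO`: > 10000 nM (a limit)
Compound 2 `COc1ccc(/C=C/C(=O)c2ccc(OC)c3c2OC(C)(C)C=C3)cc1OC(=O)C(C)C`: 250 nM

Going by the values given here, in a functional assay on HepG2 cells (Homo sapiens) for cytotoxicity, read by MTT assay (on this read-out higher numbers stand for weaker inhibition and lower numbers for stronger inhibition), compound 2 gives 250 nM, the only actual number so far. Compound 1 stands at > 10000 nM, which is a limit. Compound 3 `C=CC(=O)Oc1cc(/C=C/C(=O)c2ccc(OC)c3c2OC(C)(C)C=C3)ccc1OC` differs from compound 2 by vinyl in place of isopropyl on a carbonyl carbon. Among the compounds with values here, the one measured step, an at least 40-fold lower number from compound 1 to compound 2 (1.60 log units; beyond the scatter), is large and rests on (the limit of > 10000 nM in this assay, at which 1 of the 2 values shown sits). That step replaced the whole group on the oxygen, whereas here the carbonyl stays, so it bears only loosely. The step expected in this assay is none beyond the scatter: a 1.3-fold lower number from compound 2 to compound 3 (0.10 log units; within the scatter). For compound 3 the estimated value is 200 nM, with an expected range of 50 nM to 800 nM.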

Compound 3, half-maximal inhibitory concentration: 160 nM
For compound 3 the middle estimate is 1.3-fold (0.10 log units) above the measured one; measured number inside the range.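

In this assay, vinyl in place of isopropyl on a carbonyl carbon gives a 1.6-fold lower number from compound 2 to compound 3 (0.19 log units; within the scatter), so the two groups cannot be told apart here. Vinylcarbonyl in place of 2-hydroxyethyl gives an at least 62-fold lower number from compound 1 to compound 3 (1.79 log units; beyond the scatter), so the large step now appears with a second group on the carbonyl carbon. The size of that step is only a bound, as the value of compound 1 is a limit: the limit of > 10000 nM in this assay, at which 1 of the 3 values shown sits.

From the compounds shown here alone, a longer alkyl chain or an aminomethyl group on the carbonyl carbon remains open. Going by these compounds, whether any group without the carbonyl matches compound 2 and compound 3 also remains open.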